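A few compounds are considered here, and "the series" means these few. Any claim that something is new, unique, unknown or untested is made for them only; others in the source may bear on it.

Of the compounds shown here, three built on a shared core have been tested in a functional assay on SK-MEL-5 cells (Homo sapiens); a lower number here means a stronger inhibitor of growth, a higher number a weaker inhibitor of growth. Compound 1 `Cc1cc(C)c2c(O)cc(-c3ccc(Cl)cc3)nc2n1` gives 14100 nM, compound 2 `Oc1cc(-c2ccc(Cl)cc2)nc2ncccc12` gives 28800 nM, and compound 3 `Cc1ccnc2nc(-c3ccc(F)cc3)cc(O)c12` gives 16200 nM. Compound 3 lies within the usual scatter of both others, so these numbers do not rank the three compounds.

Compound 4 `Cc1ccnc2nc(-c3ccc(Cl)cc3)cc(O)c12` has not yet been measured. It differs from compound 3 by a single swap, chloro in place of fluoro on an aromatic carbon, para to a large group. Among the measured compounds shown here, no two measured compounds isolate this swap, so the data give no direct size for it. Still, compound 1 at 14100 nM and compound 2 at 28800 nM both carry chloro in that place, and both stay within the scatter of compound 3. No step beyond the scatter is therefore expected. The estimate amounts to a 1.1-fold lower number from compound 3 to compound 4 (0.03 log units; within the scatter), which stays within the scatter. Compound 4 is expected at about 15000 nM, with an estimated range from 7500 nM to 30000 nM.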

Compound 4, concentration for 50% growth inhibition: 3470 nM
For compound 4 the middle estimate is 4.3-fold (0.64 log units) above the measured one, and the stated range ends above it.
By their numbers in this assay, from the lowest: compound 4; then compounds 1, 3 and 2 (each within the scatter of the next, the first and the last beyond it).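

In this assay, among the compounds shown here, chloro in place of fluoro on the aromatic ring gives a 4.7-fold lower number from compound 3 to compound 4 (0.67 log units; beyond the scatter) and so makes a real difference at this position, even though only one atom changes. The methyl groups on the shared core also matter, and not in one direction: adding a methyl gives an 8.3-fold lower number from compound 2 to compound 4 (0.92 log units; beyond the scatter) while removing one gives a 4.1-fold lower number from compound 1 to compound 4 (0.61 log units; beyond the scatter) so in these compounds, more methyl does not simply mean a lower number. No measurement shown here explains why either change has this effect.

On these data alone, it remains open whether bromo or methoxy at the same position would lower the number further or raise it. Also unknown is whether a longer chain in place of the methyl of compound 4 would be tolerated.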